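Amine for ether on the chain end of compound 3

The source may hold more compounds than are shown below. What is called first, only, known or untested is meant among the compounds shown, and "the series" means these compounds.

Compound 1, `COc1cc(OCCOCCNC2CCCC2)ccc1OCc1ccccc1`: 44600 nM
Compound 2, `O=[N+]([O-])c1ccc(COc2ccc(OCCOCCNC3CCCC3)cc2)cc1`: 20300 nM
Compound 3, `c1ccc(COc2ccc(OCCOCCOC3CCCC3)cc2)cc1`: > 100000 nM

Of the compounds shown here, three have been tested in a functional assay on SK-OV-3 cells (Homo sapiens) for inhibition, read by CCK-8 assay, with a stated time of 70 h; a higher number here means a weaker inhibitor, a lower number a stronger inhibitor. Compound 1 gives 44600 nM. Compound 2 gives 20300 nM. For the measured compounds named here, compound 3 returns only a limit of the assay, > 100000 nM, so no number is known for it; this is the limit of > 100000 nM in this assay, at which 1 of the 3 values shown sits, and compound 3 is the single compound of the three that stands there.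

Compound 4, `c1ccc(COc2ccc(OCCOCCNC3CCCCC3)cc2)cc1`, has not yet been measured. It differs from compound 3 in one place: cyclohexylamino in place of cyclopentyloxy on a saturated chain carbon, two bonds along the chain from an oxygen on a saturated carbon. Compound 1 and compound 2 both carry an amino group at that end of the chain and both give numbers inside the range of this assay, whereas compound 3, with the ether, does not. On that basis the change from compound 3 to compound 4 is expected to strengthen inhibition, moving compound 4 from the limit into the measurable range, with an expected step of an at least 3.3-fold lower number from compound 3 to compound 4 (0.52 log units; beyond the scatter). Compound 4 is therefore estimated at 30000 nM, with a likely range from 10000 nM to 100000 nM.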

Compound 4, half-maximal inhibitory concentration: 7370 nM
For compound 4 the middle estimate is 4.1-fold (0.61 log units) above the measured one; measured number outside the range, below it.
By their numbers in this assay, from the lowest: compound 4; then compound 2; then compound 1. At a limit, above all of these: compound 3.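

In this assay, exchanging cyclopentyloxy for cyclohexylamino on a saturated chain carbon, two bonds along the chain from an oxygen on a saturated carbon, gives an at least 13-fold lower number from compound 3 to compound 4 (1.13 log units; beyond the scatter). For the compounds shown here, compound 1 and compound 2 each differ from compound 3 in more than one place, so only this pair shows that a change at the chain end alone, with the rest of the molecule kept, is enough to bring a compound from the limit into the measurable range. The value of compound 3 is a limit of the assay, so the step gives only the smallest size the change can have: the limit of > 100000 nM in this assay, at which 1 of the 4 values shown sits.

The change also does two things at once, replacing the oxygen with a nitrogen that adds a hydrogen-bond donor and enlarging the five-membered ring to a six-membered one, so the compounds shown cannot divide the step between the two. Cyclopentylamino or cyclohexyloxy at the same chain end on the core of compound 4 would separate them, and an open-chain amine there would show whether the ring is needed at all.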